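The compounds below may be only part of what the source reports. "The series", "measured", "known", "first", "only" and "open" are said of these compounds alone.

The measured compounds:
Compound 1, `Nc1ccccc1NC(=O)c1ccc(CSC(=S)N2CCN(Cc3ccccn3)CC2)cc1`, gives 20.7% in a functional assay on A-375 cells (Homo sapiens) for antiproliferative activity, read by CCK-8 assay, with a stated time of 72 h, tested at 2 uM; a higher number here means a stronger effect of the compound at the concentration tested, a lower number a weaker effect.
Compound 2, `CC1CCN(C(=S)SCc2ccc(C(=O)Nc3ccccc3N)cc2)CC1`, gives 32.7% in this assay.

Compound 1 stands lowest of the two numbers; its nearest neighbour is compound 2, whose number is higher by more than the usual scatter. Compound 3, `N#Cc1ccc(N2CCN(C(=S)SCc3ccc(C(=O)Nc4ccccc4N)cc3)CC2)cc1`, has not yet been tested in this assay. It differs from compound 1 in one place: 4-cyanophenyl in place of (pyridin-2-yl)methyl on an amine nitrogen in a ring. Among the compounds with values here, no step between two measured compounds touches this position, so the effect of the change cannot be read from a measured pair, and the expectation rests only on the two numbers above. Compound 1 and compound 2 both carry the shared core and differ only in the ring on the dithiocarbamate side, with compound 2 at 32.7%. The step of a number 9.3 percentage points higher from compound 1 to compound 3 (within the scatter) is estimated to be upward and small, near the edge of the scatter. Compound 3 is expected to give 30%, within a range from 12% to 50%.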

Compound 3, a percentage reported as inhibition, at one concentration (the size of the read-out at that concentration, not a potency): 41.4%
Estimate against measurement, compound 3: 11.4 percentage points below; measured number inside the range.
By their numbers in this assay, from the lowest: compound 1; then compounds 2 and 3 (each within the scatter of the next).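

In this assay, the position on the amine nitrogen in the ring proves responsive to its substituent: with 4-cyanophenyl in place of (pyridin-2-yl)methyl, the number moves a number 20.7 percentage points higher from compound 1 to compound 3 (beyond the scatter). The earlier compounds shown here could not show this, as no measured pair isolated this change, and here a swap of one six-membered aromatic ring group for another moves the read-out beyond the scatter. Nothing at hand accounts for the size or direction of this step.

Within the data shown here, the single step leaves open whether the nitrile, the carbon-only aromatic ring or the absence of the methyl link in (pyridin-2-yl)methyl matters most. How a plain phenyl, a benzyl or a 4-aminophenyl group would read on this nitrogen remains an open question.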